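The compounds below may be only part of what the source reports. "The series", "measured", "known", "first", "only" and "open" are said of these compounds alone.

Compound 1: `O=C(Nc1ccccc1O)c1c(NO)cc(-c2ccccc2)oc1=O`, 14000 nM.
Compound 2: `O=C(Nc1ccccc1)c1c(NO)cc(-c2cccs2)oc1=O`, > 20000 nM.

Of the compounds shown here, two sharing one core have been tested in an ADME assay on Huh-7 cells (Homo sapiens) for cytotoxicity, with a stated time of 3 days; on this read-out lower numbers stand for higher toxicity in this test and higher numbers for lower toxicity in this test. Compound 1, `O=C(Nc1ccccc1O)c1c(NO)cc(-c2ccccc2)oc1=O`, gives 14000 nM. For compound 2, `O=C(Nc1ccccc1)c1c(NO)cc(-c2cccs2)oc1=O`, the test returns a limit rather than a number, > 20000 nM. This places compound 2 at the limit of > 20000 nM in this assay, at which 1 of the 2 values shown sits, so its true value is known only to lie on the less toxic side of that point.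

Compound 3, `O=C(Nc1ccc(F)cc1)c1c(NO)cc(-c2cccs2)oc1=O`, has not yet been measured. It differs from compound 2 by fluoro in place of hydrogen on an aromatic carbon. Going by the values given here, no pair of measured compounds shows what such a change does to this read-out, so nothing here points to a shift in either direction. The expected step is a number no higher from compound 2 to compound 3 (the limit leaves the size open), nothing beyond the usual scatter. Compound 3 is therefore expected to give 20000 nM, in the range 8000 nM to 50000 nM, and the measurement will most likely again end as a limit of the test.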

Compound 3, half-maximal cytotoxic concentration: > 20000 nM
Compound 3: no number, only a limit (the forecaster's own chance of this, stated with the estimate: 65%); the middle value sits exactly at the limit.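

In this assay compound 3 returns a limit, > 20000 nM, and not a number. Compound 2 also ends at a limit, so no step can be read between compound 2 and compound 3: the limit of > 20000 nM in this assay, at which 2 of the 3 values shown sit.

The compounds shown leave open whether swapping phenyl for 4-fluorophenyl changes toxicity in this test at all.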